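The source may report more compounds than this note shows. Statements on the series, on what has been measured and on what is new or still open speak of the compounds shown alone.

Measured so far in a functional assay on COLO 205 cells (Homo sapiens) for cytotoxicity, read by MTT assay, with a stated time of 72 h; on this read-out higher numbers stand for weaker inhibition and lower numbers for stronger inhibition:
compound 1 `COc1ccc(/C=C/C(=O)Nc2cc(C(=O)c3cc(OC)c(OC)c(OC)c3)ccc2OC)cc1` gives 10900 nM
compound 2 `COc1ccc(C(=O)c2cc(OC)c(OC)c(OC)c2)cc1NC(=O)/C=C/c1ccc(N)cc1` gives 10300 nM
compound 3 `COc1ccc(/C=C/C(=O)Nc2cc(C(=O)c3cc(OC)c(OC)c(OC)c3)cc(OC)c2OC)cc1` gives 4800 nM

Compound 3 stands at the lowest number of the three, meaning the strongest inhibition, and its gaps to the other two are beyond the scatter: the step of a 2.3-fold lower number from compound 1 to compound 3 (0.36 log units; beyond the scatter) shows the larger gap, and compound 2 sits only slightly above compound 3. Compound 4 `COc1cc(C(=O)c2cc(OC)c(OC)c(OC)c2)cc(NC(=O)/C=C/c2ccc(F)cc2)c1OC` differs from compound 3 in one place: fluoro in place of methoxy on an aromatic carbon. Going by the values given here, one measured step concerns this same spot: a 1.1-fold lower number from compound 1 to compound 2 (0.02 log units; within the scatter), an exchange of the group at that position that left the number effectively unchanged. The other step, a 2.3-fold lower number from compound 1 to compound 3 (0.36 log units; beyond the scatter), concerns a different place and is already part of compound 3. Among the compounds with values here, with the only exchange on record at this spot showing no effect, no step beyond the scatter is expected here: a 1.0-fold higher number from compound 3 to compound 4 (0.02 log units; within the scatter). Compound 4 is accordingly estimated at 5000 nM, with the expected range running from 2000 nM to 12500 nM.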

Compound 4, half-maximal inhibitory concentration: 3100 nM
Compound 4: the middle estimate sits 1.6-fold (0.21 log units) above what was measured; the measured number falls inside the stated range.
By their numbers in this assay, from the lowest: compounds 4 and 3 (each within the scatter of the next); then compounds 2 and 1 (each within the scatter of the next).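

In this assay, the exchange of methoxy for fluoro on the 4-methoxyphenyl ring gives a 1.5-fold lower number from compound 3 to compound 4 (0.19 log units; within the scatter). The earlier compounds shown here showed only amino replacing methoxy at this spot, on the core without the extra methoxy, in a 1.1-fold lower number from compound 1 to compound 2 (0.02 log units; within the scatter); this result adds a second, quite different replacement, on the core that carries the extra methoxy, and that step also stays within the scatter. No supporting evidence is available to explain why these exchanges at this spot leave the number within the scatter.

The compounds shown leave open whether a group such as a carboxylic acid, a trifluoromethyl or a longer alkoxy chain at this spot would move the number beyond the scatter. They also leave open whether fluoro on the core of compound 1 would behave as it does on the core of compound 3.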